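From 3-chlorophenyl to 1,3-thiazol-2-yl on a sulfonamide nitrogen

The source may report more compounds than this note shows. Statements on the series, on what has been measured and on what is new or still open speak of the compounds shown alone.

In a functional assay on RAW264.7 cells (Mus musculus) for inhibition (a higher number here means a weaker inhibitor, a lower number a stronger inhibitor), compound 1 `CCOC(=O)C1=CCCCC1S(=O)(=O)Nc1ccc(F)cc1` gives 110 nM, compound 2 `CCOC(=O)C1=CCCCC1S(=O)(=O)Nc1ccccc1Cl` gives 12 nM and compound 3 `CCOC(=O)C1=CCCCC1S(=O)(=O)Nc1cccc(Cl)c1` gives 66 nM. The data show a 1.7-fold lower number from compound 1 to compound 3 (0.22 log units; within the scatter), so compound 3 is not separated from compound 1. They also show a 5.5-fold higher number from compound 2 to compound 3 (0.74 log units; beyond the scatter), and a 9.2-fold lower number from compound 1 to compound 2 (0.96 log units; beyond the scatter), so only compound 2 stands apart.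

Compound 4 `CCOC(=O)C1=CCCCC1S(=O)(=O)Nc1nccs1` carries a larger change, 1,3-thiazol-2-yl in place of 3-chlorophenyl on a sulfonamide nitrogen. The measured steps only exchange one substituted phenyl for another, and none places a five-membered aromatic ring on that nitrogen. They therefore bear on this change only indirectly, showing that swaps at this place can reach a modest size. The direction remains uncertain, but a modest move towards a higher number is expected in this assay. The estimated step is a 3.8-fold higher number from compound 3 to compound 4 (0.58 log units; beyond the scatter). Compound 4 is expected at 250 nM, with an estimated range from 50 nM to 1200 nM.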

Compound 4, half-maximal inhibitory concentration: > 10000 nM
Compound 4 gave a limit, no number; the forecaster's own chance of this, stated with the estimate: 10%; middle value at least 40-fold (1.60 log units) away from the limit.
By their numbers in this assay, from the lowest: compound 2; then compounds 3 and 1 (each within the scatter of the next). At a limit, above all of these: compound 4.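

In this assay compound 4 gives no number, only a limit: the limit of > 10000 nM in this assay, at which 1 of the 4 values shown sits. Swapping a halogen-bearing phenyl group for 1,3-thiazol-2-yl gives an at least 150-fold higher number from compound 3 to compound 4 (2.18 log units; beyond the scatter) and an at least 830-fold higher number from compound 2 to compound 4 (2.92 log units; beyond the scatter) and also an at least 90-fold higher number from compound 1 to compound 4 (1.95 log units; beyond the scatter). Going by these compounds alone, all three steps are large, whereas exchanges among the phenyl groups reached only a modest size, so this place on the sulfonamide nitrogen is far more sensitive to a change of ring than the earlier compounds showed.

The compounds shown leave open whether this rise belongs to the five-membered ring, to its hetero atoms or to the loss of the halogen; a pyridin-2-yl or a thiophen-2-yl group on that nitrogen would help to separate these. As far as these compounds go, how far the true value of compound 4 lies beyond its limit also remains open.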